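The compounds below may be only part of what the source reports. "The series", "measured", "known", "first", "only" and "open" are said of these compounds alone.

Among the measured compounds shown here, in a functional assay on A-375 cells (Homo sapiens) for antiproliferative activity (on this read-out lower numbers stand for stronger inhibition and higher numbers for weaker inhibition), compound 2 `O=C(Nc1ccc(-c2cscn2)cc1)C1CCCN(Cc2ccccc2F)C1` gives 4000 nM, the only exact number so far. Compound 1 `O=C(Nc1ccc2scnc2c1)C1CCCN(Cc2ccc(F)c(F)c2)C1` reads > 20000 nM, which is a limit of the assay and not a number. Compound 3 `O=C(Nc1ccc(-c2cscn2)cc1)C1CCCN(Cc2cc(F)c(F)c(F)c2)C1` carries 3,4,5-trifluorophenyl in place of 2-fluorophenyl on a saturated chain carbon bound to an amine nitrogen in a ring. For the measured compounds named here, no measured pair in this assay isolates this change, so only a modest shift towards weaker inhibition is expected. The estimated step is a 1.5-fold higher number from compound 2 to compound 3 (0.18 log units; within the scatter). For compound 3 the expected value is 6000 nM, within an estimated range of 2000 nM to 20000 nM.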

Compound 3, half-maximal inhibitory concentration: 400 nM
Compound 3: the middle estimate sits 15-fold (1.18 log units) above what was measured; measured number outside the range, below it.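

The group on a saturated chain carbon bound to an amine nitrogen in a ring clearly matters in this assay: 3,4,5-trifluorophenyl in place of 2-fluorophenyl gives a 10-fold lower number from compound 2 to compound 3 (1.00 log units; beyond the scatter). Among the compounds shown here, this is the only single-place change so far, and it shows that this position alone can move the read-out beyond the scatter. Nothing measured here gives a cause for this step.

The two groups differ in both the number and the placement of their fluorines, and the compounds shown do not separate these two changes. On these data alone, how phenyl without fluorine or 4-methoxyphenyl would read at this position remains open.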